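The compounds below may be only part of what the source reports. "The series", "measured", "known", "first", "only" and "open" are said of these compounds alone.

Working notes on the series.

Among the measured compounds shown here, compound 1 `COc1cc(Cn2cc(COc3cccc(/C=C4/C(=O)Nc5ccccc54)c3)nn2)cc(OC)c1` is the one member with a number so far: in a functional assay on HeLa cells (Homo sapiens) for inhibition, read by MTT assay, with a stated time of 48 h (a lower number here means a stronger inhibitor, a higher number a weaker inhibitor), compound 1 gives 22000 nM. Compound 2 `O=C1Nc2ccc(Cl)cc2/C1=C/c1cccc(OCc2cn(Cc3ccccc3)nn2)c1` shares the benzylidene oxindole and triazole arrangement but carries a chloro on the fused ring and a benzyl on the triazole; in this assay compound 2 gives "not determined" (no result reported), so no single number is available for it. Compound 2 therefore stands nowhere on the numbers shown, and no step between measured compounds links it to compound 1.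

Compound 3 `O=C1Nc2ccc(Br)cc2/C1=C/c1cccc(OCc2cn(Cc3ccccc3)nn2)c1` is the next point. The change from compound 2 is bromo in place of chloro on an aromatic carbon. With no measured step to anchor it, the expectation for a swap of this kind in this assay is a shift in neither direction beyond the usual scatter. For compound 3 the estimated value in this assay is 12000 nM, with an expected range from 3000 nM to 40000 nM.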

Compound 3, half-maximal inhibitory concentration: > 50000 nM
Compound 3 was reported as a limit; the forecaster's own chance of this, stated with the estimate: 20%; at least 4.1-fold (0.61 log units) between middle value and limit.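

Compound 3 gives > 50000 nM in this assay, which is a limit and not a number. With no single number for compound 2 either, no new step can be read between compound 2 and compound 3. The compounds shown leave open whether bromo in place of chloro shifts the value at all.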